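Aryl swap on the amide nitrogen: compound 1 to compound 3

The source may report more compounds than this note shows. Statements on the series, on what has been measured and on what is new or still open speak of the compounds shown alone.

Compound 1 `COc1cccc(NC(=O)/C=C/c2coc3cc(OC)ccc3c2=O)c1` is the anchor of this note. In a functional assay on L02 cells (Homo sapiens) for inhibition, read by MTT assay, with a stated time of 48 h (on this read-out lower numbers stand for stronger inhibition and higher numbers for weaker inhibition), compound 1 returns only a limit, > 200000 nM. Compound 2 `COc1ccc(NC(=O)/C=C/c2coc3cc(O)ccc3c2=O)cc1` likewise returns only a limit in this assay, > 200000 nM. Both measured entries therefore sit at the limit of > 200000 nM in this assay, at which 2 of the 2 values shown sit, so compound 1 carries no number, only that ceiling. Compound 3 `COc1ccc2c(=O)c(/C=C/C(=O)Nc3ccc(C)cc3)coc2c1` differs from compound 1 by 4-methylphenyl in place of 3-methoxyphenyl on an amide-type nitrogen. Within the data shown here, no measured step between compounds exists, so the change is judged from the structures alone. The expected step that the limit leaves unreadable from compound 1 to compound 3 is none beyond the scatter, with a limit again the likeliest outcome. Compound 3 is accordingly estimated at 250000 nM, within 60000 nM to 600000 nM.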

Compound 3, half-maximal inhibitory concentration: > 200000 nM
Compound 3 was reported as a limit; the forecaster's own chance of this, stated with the estimate: 80%; the middle value is on the limit's open side.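

Compound 3, like compound 1, stands only as a limit in this assay, so no step can be read between them: the limit of > 200000 nM in this assay, at which 3 of the 3 values shown sit. The compounds shown leave open whether any aryl group on the amide-type nitrogen gives a readable value in this assay.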